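Quinazoline series: aniline swap at the sulfonamide-bearing core

The compounds below may be only part of what the source reports. "The series", "measured", "known", "first", "only" and "open" are said of these compounds alone.

Measured so far in a functional assay on HCT-116 cells (Homo sapiens) for antiproliferative activity, read by sulforhodamine B assay, with a stated time of 72 h; on this read-out higher numbers stand for weaker inhibition and lower numbers for stronger inhibition:
- compound 1 `COc1ncc(-c2ccc3ncnc(Nc4ccc(OCCO)cc4)c3c2)cc1NS(C)(=O)=O`: 4860 nM
- compound 2 `COC(=O)Cn1cc(Nc2ncnc3ccc(-c4cnc(OC)c(NS(=O)(=O)c5ccc(F)cc5F)c4)cc23)cn1`: 1260 nM
- compound 3 `CCCCS(=O)(=O)Nc1cc(-c2ccc3ncnc(Nc4ccc(OCCO)nc4)c3c2)cnc1OC`: limit, > 20000 nM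

Compound 2 gives the lowest of the two numbers shown in this assay; the nearest number, that of compound 1, lies higher by a gap that is beyond the usual scatter. For compound 3 the figure in this assay is a limit of the assay and not a number, > 20000 nM. One such limit is among the three values (the limit of > 20000 nM in this assay, at which 1 of the 3 values shown sits).

The next compound, compound 4 `COc1cc(Nc2ncnc3ccc(-c4cnc(OC)c(NS(=O)(=O)c5ccc(F)cc5F)c4)cc23)ccc1OCCO`, keeps the shared core of compound 2 together with its 2,4-difluorophenylsulfonamide and differs from it in one place:
4-(2-hydroxyethoxy)-3-methoxyphenyl in place of 1-((methoxycarbonyl)methyl)-1H-pyrazol-4-yl on a nitrogen on an aromatic ring
Among the compounds with values here, no step between two measured compounds isolates this change. Compound 1 carries a 2-hydroxyethoxyphenyl group on the same nitrogen, but with a different sulfonamide, so it gives only a loose point of comparison. The step in this assay from compound 2 to compound 4 is expected to be small, perhaps a modest rise in the number and within or near the scatter, as a 1.3-fold higher number from compound 2 to compound 4 (0.10 log units; within the scatter). On that basis compound 4 is estimated at 1600 nM in this assay, with a plausible range from 450 nM to 6000 nM.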

Compound 4, half-maximal inhibitory concentration: 5720 nM
Compound 4: middle estimate off by 3.6-fold (0.55 log units), on the low side; the measured number falls inside the stated range.
By their numbers in this assay, from the lowest: compound 2; then compounds 1 and 4 (each within the scatter of the next). At a limit, above all of these: compound 3.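

Within the data shown here, with the 2,4-difluorophenylsulfonamide and the shared core held fixed, this is the only change so far that can be read on its own: in this assay, placing 4-(2-hydroxyethoxy)-3-methoxyphenyl on the nitrogen instead of 1-((methoxycarbonyl)methyl)-1H-pyrazol-4-yl gives a 4.5-fold higher number from compound 2 to compound 4 (0.66 log units; beyond the scatter). The earlier compounds shown here could not show that this position responds to the group it carries, even with the sulfonamide unchanged, and of this pair the pyrazole-bearing compound 2 has the lower number. Nothing measured here bears on the origin of this step.

Among these compounds, it remains open whether the step follows the aromatic ring itself, the methoxy group or the 2-hydroxyethoxy chain, as no pair in the set separates these parts of the entering group. Also open, as far as these compounds go, are whether a carboxylic acid or a primary amide in place of the methoxycarbonyl group on the pyrazole side chain would keep the number of compound 2, and whether the same swap gives a step of similar size on a different sulfonamide.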